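Cytotoxicity Limits Across Three Measured Compounds

The source may report more compounds than this note shows. Statements on the series, on what has been measured and on what is new or still open speak of the compounds shown alone.

Compound 1 `CCC1(Cc2ccccc2)OS(=O)(=O)C=C1OCc1ccccc1` gives >= 50000 nM in an ADME assay on HEL cells (Homo sapiens) for cytotoxicity, with a stated time of 3 days; on this read-out lower numbers stand for higher toxicity in this test and higher numbers for lower toxicity in this test.
Compound 2 `CCC1(Cc2ccccc2)OS(=O)(=O)C=C1OCC#N` gives > 400000 nM in this assay.
Compound 3 `CCC1(Cc2ccccc2)OS(=O)(=O)C=C1OCc1ccccc1Cl` gives >= 20000 nM in this assay.

Each of these three values is a limit of the test, not a measured number. Compound 3 therefore stands at the limit of >= 20000 nM in this assay, at which 1 of the 3 values shown sits, and its position relative to the others cannot be read. The change to compound 4 `CCC1(Cc2ccccc2)OS(=O)(=O)C=C1OCC1CCCCC1` is cyclohexyl in place of 2-chlorophenyl on a saturated chain carbon bound to an oxygen on an unsaturated carbon. The steps that touch the same position, a step that the two limits leave unreadable from compound 1 to compound 3 and a step that the two limits leave unreadable from compound 2 to compound 3, are both unreadable, since they join two limits. No direction or size can be drawn from them. Compound 4 is expected to sit near 50000 nM, within 15000 nM to 400000 nM, most likely again as a limit. The expected step that the limit leaves unreadable from compound 3 to compound 4 is therefore not beyond the scatter.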

Compound 4, minimum cytotoxic concentration: >= 200000 nM
Compound 4: only a limit was reported; the forecaster's own chance of this, stated with the estimate: 80%; at least 4.0-fold (0.60 log units) between middle value and limit.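

Among these compounds, the result for compound 4 is again a limit, like those of compound 1, compound 2 and compound 3, so no step to compound 4 can be read. The compounds shown leave open the actual cytotoxic concentration of each one, and whether cyclohexyl, 2-chlorophenyl, phenyl or cyano at this place makes any difference in this assay.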